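Methyl carbamate to methyl urea on the benzylic amine

The compounds below may be only part of what the source reports. "The series", "measured", "known", "first", "only" and "open" are said of these compounds alone.

Measured so far:
compound 1, `CCCCCCCCN1C(=O)[C@H](Cc2ccc(-c3cccc(CN(CCCC)C(=O)OC)c3)cc2)N(C)C(=O)[C@@H]1C`: 2.7 nM
compound 2, `CCCCCCCCN1C(=O)[C@H](Cc2ccc(-c3cccc(CN(CCCC)C(=O)NC)c3)cc2)N(C)C(=O)[C@@H]1C`: 1.2 nM
compound 3, `CCCCCCCCN1C(=O)[C@H](Cc2ccc(-c3cccc(CN(COC)C(=O)OC)c3)cc2)N(C)C(=O)[C@@H]1C`: 1.8 nM

All three were run in a functional assay for agonist activity at follicle-stimulating hormone receptor (Homo sapiens), read by a luciferase reporter; on this read-out lower numbers stand for an effect already at smaller amounts and higher numbers for an effect only at larger amounts of compound. Compounds 1 and 2 share a core and differ only in the change (methylamino in place of methoxy on a carbonyl carbon); that change gave a 2.3-fold lower number from compound 1 to compound 2 (0.35 log units; beyond the scatter). Compound 3 carries a different core; how it differs from compound 1 is counted in methoxy in place of propyl on a saturated chain carbon bound to an amide-type nitrogen, and the two cores sit close in this assay, with a 1.5-fold lower number from compound 1 to compound 3 (0.18 log units; within the scatter). Compound 2 and compound 3 also lie near each other, with a 1.5-fold higher number from compound 2 to compound 3 (0.18 log units; within the scatter).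

Compound 4, `CCCCCCCCN1C(=O)[C@H](Cc2ccc(-c3cccc(CN(COC)C(=O)NC)c3)cc2)N(C)C(=O)[C@@H]1C`, is not yet measured. It stands to compound 3 as compound 2 stands to compound 1: the change is methylamino in place of methoxy on a carbonyl carbon, and the place of the change reads the same in both pairs, a carbonyl carbon whose other neighbour is an amide-type nitrogen. So this is the same change, made on the second core.

The expectation for compound 4 rests on one precedent only. Within the data shown here, the step from compound 3 to compound 4 in this assay is estimated to be about a 2.3-fold lower number from compound 3 to compound 4 (0.35 log units; beyond the scatter), set beside the measured 2.3-fold lower number from compound 1 to compound 2 (0.35 log units; beyond the scatter), on the assumption that the core of compound 3 does not alter the effect of the change; compound 3 is the only other core here and the single precedent gives no way to test that. For compound 4 the expected value in this assay is 0.8 nM, with a range from 0.35 nM to 1.8 nM.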

Compound 4, half-maximal effective concentration: 3.6 nM
Beside the measured number, compound 4's estimate is 4.5-fold (0.65 log units) below it; measured number outside the range, above it.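

In this assay, methylamino in place of methoxy on a carbonyl carbon does not carry over from the first core to the second, where it gives a 2.0-fold higher number from compound 3 to compound 4 (0.30 log units; within the scatter), so the earlier gain does not reappear: the same change on two cores in this assay, a 2.3-fold lower number (0.35 log units; beyond the scatter) from compound 1 to compound 2 and a 2.0-fold higher number (0.30 log units; within the scatter) from compound 3 to compound 4, 4.5-fold (0.65 log units) apart, beyond the scatter of two such steps. Read the other way round, methoxy in place of propyl on a saturated chain carbon bound to an amide-type nitrogen gives a 3.0-fold higher number from compound 2 to compound 4 (0.48 log units; beyond the scatter) on the ureas, and this step too differs from its counterpart on the carbamates: the same change on two cores in this assay, a 1.5-fold lower number (0.18 log units; within the scatter) from compound 1 to compound 3 and a 3.0-fold higher number (0.48 log units; beyond the scatter) from compound 2 to compound 4, 4.5-fold (0.65 log units) apart, beyond the scatter of two such steps. Made together, the two changes give a 1.3-fold higher number from compound 1 to compound 4 (0.12 log units; within the scatter); this single set of four compounds shows that the carbamate-to-urea step cannot be treated as a constant between these two cores, but it does not show what in the butyl and methoxymethyl chains sets the difference, nor which way the step would go on any further core.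

Open, as far as these compounds go, is whether a pentyl or a 2-methoxyethyl chain in that place would behave like butyl or like methoxymethyl when the methoxy is exchanged. Also open, from the compounds shown here alone, is how an ethylamino or a dimethylamino group on the carbonyl carbon would read on each of the two cores.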